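A further methoxy on compound 3

A few compounds are considered here, and "the series" means these few. Any claim that something is new, unique, unknown or untested is made for them only; others in the source may bear on it.

Values in a functional assay on HeLa cells (Homo sapiens) for cytotoxicity, read by MTT assay, with a stated time of 48 h; on this read-out higher numbers stand for weaker inhibition and lower numbers for stronger inhibition:
compound 1 `COc1cc(OC)c(OC)cc1/C=C/C(=O)/C=C/c1cc2ccccc2nc1Cl` gives 5410 nM
compound 2 `COc1ccc(/C=C/C(=O)/C=C/c2cc3ccccc3nc2Oc2ccccc2)c(OC)c1` gives > 10000 nM (a limit)
compound 3 `COc1ccc(/C=C/C(=O)/C=C/c2cc3ccccc3nc2Oc2ccccc2)cc1OC` gives > 10000 nM (a limit)

Compound 3 stands at the limit of > 10000 nM in this assay, at which 2 of the 3 values shown sit, and so offers no number to step from. Compound 4 `COc1cc(OC)c(OC)cc1/C=C/C(=O)/C=C/c1cc2ccccc2nc1Oc1ccccc1` follows from compound 3 by methoxy in place of hydrogen on an aromatic carbon. Among the measured compounds shown here, the one measured step is a step that the two limits leave unreadable from compound 2 to compound 3 and gives no size to carry over. Compound 4 shares its methoxy groups with compound 1, which gives 5410 nM in this assay and differs from it elsewhere. Only a modest move toward stronger inhibition is therefore expected, and the estimated step is an at least 1.1-fold lower number from compound 3 to compound 4 (0.04 log units; that floor lies within the scatter) with a real chance of another limit. Compound 4 is estimated at 9000 nM (range 4000 nM to 20000 nM).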

Compound 4, half-maximal inhibitory concentration: 12200 nM
Beside the measured number, compound 4's estimate is 1.4-fold (0.13 log units) below it, and the stated range covers the measured number.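

With the added methoxy, compound 4 is the first phenoxy compound shown to give a number rather than a limit in this assay. Compound 2 and compound 3 stay at a limit, so their steps to compound 4 cannot be read: the limit of > 10000 nM in this assay, at which 2 of the 4 values shown sit. Phenoxy in place of chloro on an aromatic carbon gives a 2.3-fold higher number from compound 1 to compound 4 (0.35 log units; beyond the scatter), which is the only readable step at that place.

From the compounds shown here alone, whether the added methoxy itself changes the read-out stays open. So does the effect of an amine or a carboxylic acid in place of the phenoxy.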